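The source may hold more compounds than are shown below. What is called first, only, known or untested is meant among the compounds shown, and "the series" means these compounds.

Three compounds sharing one core, and differing only in the aromatic ring on the amide carbonyl, have been measured in a functional assay on MKN-1 cells (Homo sapiens) for inhibition, read by colorimetric assay and sulforhodamine B assay, with a stated time of 48 h; on this read-out lower numbers stand for stronger inhibition of growth and higher numbers for weaker inhibition of growth. Compound 1 `CCCCCCCCCCCC[C@@H](O)[C@H]1CC[C@H]([C@H](O)CCCCCCCCCCNC(=O)c2ccco2)O1`, with furan-2-yl, gives 100000 nM, and compound 2 `CCCCCCCCCCCC[C@@H](O)[C@H]1CC[C@H]([C@H](O)CCCCCCCCCCNC(=O)c2cncs2)O1`, with 1,3-thiazol-5-yl, gives 100000 nM. Compound 3 `CCCCCCCCCCCC[C@@H](O)[C@H]1CC[C@H]([C@H](O)CCCCCCCCCCNC(=O)c2ccsc2)O1`, with thiophen-3-yl, gives 2290 nM, the lowest of the three numbers and so the strongest inhibition of growth in the set.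

Compound 4 `CCCCCCCCCCCC[C@@H](O)[C@H]1CC[C@H]([C@H](O)CCCCCCCCCCNC(=O)c2ccnn2C)O1` has 1-methyl-1H-pyrazol-5-yl in place of thiophen-3-yl on a carbonyl carbon. Among the compounds with values here, no measured compound carries this ring, so the evidence is indirect. The large steps of a 44-fold lower number from compound 1 to compound 3 (1.64 log units; beyond the scatter) and a 44-fold lower number from compound 2 to compound 3 (1.64 log units; beyond the scatter) show that this ring exchange can move the number a long way, while no change at the digits printed from compound 1 to compound 2 (within the scatter) shows that two different rings can give the same high number. In this small set, thiophen-3-yl alone gives a low number, and neither other ring comes close to it. A rise in this assay is therefore expected, perhaps somewhat smaller than those large steps. The expected change is a 13-fold higher number from compound 3 to compound 4 (1.12 log units; beyond the scatter), towards weaker inhibition of growth. Compound 4 is estimated at 30000 nM, with an expected range from 5000 nM to 100000 nM.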

Compound 4, concentration for 50% growth inhibition: 43700 nM
Compound 4: middle estimate off by 1.5-fold (0.16 log units), on the low side; the measured number falls inside the stated range.
By their numbers in this assay, from the lowest: compound 3; then compound 4; then compounds 1 and 2 (each within the scatter of the next).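

In this assay, 1-methyl-1H-pyrazol-5-yl in place of thiophen-3-yl on a carbonyl carbon gives a 19-fold higher number from compound 3 to compound 4 (1.28 log units; beyond the scatter) and so does not keep the low number that thiophen-3-yl gave, which leaves compound 3 still alone at the low end of the set. Within the data shown here, the new ring also does not simply join the two rings that shared the highest number: a 2.3-fold lower number from compound 1 to compound 4 (0.36 log units; beyond the scatter) and a 2.3-fold lower number from compound 2 to compound 4 (0.36 log units; beyond the scatter) are modest steps but lie beyond the scatter, so this position now shows a graded order among the weaker rings and not only one low number against one shared high number. Nothing available here accounts for this order of the rings.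

As far as these compounds go, what a phenyl ring or thiophen-2-yl on the same carbonyl carbon would give remains open, and with it whether the low number belongs to thiophen-3-yl alone. Also open, from the compounds shown here alone, is whether the same order of the rings would hold with a shorter chain on the amide nitrogen.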